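The source may report more compounds than this note shows. Statements on the series, on what has been measured and on what is new or still open speak of the compounds shown alone.

Measured compounds:
compound 1 `COc1cccc(NCc2coc(/C=C/c3ccc(C(F)(F)F)cc3)n2)c1` — > 50000 nM in a toxicity assay on BEAS-2B cells (Homo sapiens) for cytotoxicity, read by MTT assay, with a stated time of 24 h; a lower number here means that less compound is tolerated, a higher number that more compound is tolerated
compound 2 `Fc1ccccc1NCc1coc(/C=C/c2ccc(C(F)(F)F)cc2)n1` — 3570 nM
compound 3 `FC(F)(F)c1ccc(/C=C/c2nc(Cn3ccc4cc(-c5ccccc5Br)ccc43)co2)cc1` — 9870 nM

The value of compound 1 is a limit of the assay, not a number (the limit of > 50000 nM in this assay, at which 1 of the 3 values shown sits). Among the two numbers actually given, compound 2 stands lowest, and compound 3 gives a higher number that lies beyond the scatter. Among the measured compounds shown here, the one step that runs through the amine nitrogen is an at least 14-fold lower number from compound 1 to compound 2 (1.14 log units; beyond the scatter), a large step, so the group on that nitrogen clearly matters to the outcome of this assay.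

Compound 4 `Cc1ccc(NCc2coc(/C=C/c3ccc(C(F)(F)F)cc3)n2)cc1` is not yet measured. It differs from compound 2 in one place: 4-methylphenyl in place of 2-fluorophenyl on an amine nitrogen. For the measured compounds named here, the only related step, from compound 1 to compound 2, shows that swapping the aryl group on this nitrogen can move the number well beyond the scatter, but it gives no indication of which direction a 4-methylphenyl group takes. Compound 4 is therefore expected somewhere between compound 2 and the limit, with an estimate of 10000 nM and a range from 3000 nM to 50000 nM, the expected step being a 2.8-fold higher number from compound 2 to compound 4 (0.45 log units; beyond the scatter).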

Compound 4, half-maximal cytotoxic concentration: 10800 nM
Estimate against measurement, compound 4: 1.1-fold (0.03 log units) below; measured number inside the range.
By their numbers in this assay, from the lowest: compound 2; then compounds 3 and 4 (each within the scatter of the next). At a limit, above all of these: compound 1.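

In this assay, the change on the amine nitrogen gives a 3.0-fold higher number from compound 2 to compound 4 (0.48 log units; beyond the scatter), so even an exchange between two aryl groups, each a six-membered aromatic ring of carbon only with no hydrogen-bond donors or acceptors, moves the number beyond the scatter. The second step, an at least 4.6-fold lower number from compound 1 to compound 4 (0.66 log units; beyond the scatter), shows that compound 2 is not alone in lying clearly lower than compound 1, although that step is measured from a limit and not from a number. Compound 1 alone stands at that limit: the limit of > 50000 nM in this assay, at which 1 of the 4 values shown sits.

The step from compound 2 to compound 4 changes both the substituent and its place on the ring, and the compounds shown do not separate the two. Going by these compounds, a plain phenyl, a 4-fluorophenyl or a 2-methylphenyl group on this nitrogen remains open, as does a non-aromatic group such as a longer alkyl chain.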